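The compounds below may be only part of what the source reports. "The series", "measured", "known", "first", "only" and "open" are said of these compounds alone.

Of the compounds shown here, three have been tested in a functional assay on DU-145 cells (Homo sapiens) for cytotoxicity, read by MTT assay; a lower number here means a stronger inhibitor, a higher number a weaker inhibitor. Compound 1, `CC(O)(CS(=O)(=O)c1ccc(Br)cc1)c1nc(-c2ccc([N+](=O)[O-])c(C(F)(F)F)c2)no1`, gives only a limit of the assay rather than a number in this assay, > 100000 nM; that is the limit of > 100000 nM in this assay, at which 1 of the 3 values shown sits. Compound 2, `CC(O)(CSc1ccc(F)cc1)c1nc(-c2ccc(Cl)cc2)no1`, gives 36300 nM in this assay. Compound 3, `CC(O)(CSc1ccc(Cl)cc1)c1nc(-c2ccccc2)no1`, gives 70700 nM in this assay; its number is the larger of the two reported, but the gap to compound 2 lies within the usual scatter, so no real difference between the two is shown. Compound 4, `CC(O)(CSc1ccc(F)cc1)c1nc(-c2ccccc2)no1`, has not yet been measured. It differs from compound 3 by fluoro in place of chloro on an aromatic carbon: a fluoro in place of chloro on an aromatic carbon, para to a large group. For the measured compounds named here, no pair of measured compounds isolates this exchange, so nothing here shows how large its effect is. The expectation is therefore no step beyond the scatter, and the estimated step is a 1.0-fold lower number from compound 3 to compound 4 (0.00 log units; within the scatter). Compound 4 is expected to give about 70000 nM in this assay, within a range of 30000 nM to 160000 nM.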

Compound 4, half-maximal inhibitory concentration: > 100000 nM
Compound 4 gave a limit, no number; the forecaster's own chance of this, stated with the estimate: 25%; middle value at least 1.4-fold (0.15 log units) from the limit.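

Compound 4 gives only a limit of the assay, not a number, and it is not alone there: the limit of > 100000 nM in this assay, at which 2 of the 4 values shown sit. In this assay, the change from 4-chlorophenyl to 4-fluorophenyl comes to an at least 1.4-fold higher number from compound 3 to compound 4 (0.15 log units; that floor lies within the scatter), so this exchange brings no gain in strength, although a floor cannot give its true size. The clearer result is an at least 2.7-fold higher number from compound 2 to compound 4 (0.44 log units; beyond the scatter), a real weakening when hydrogen replaces chloro on an aromatic carbon.

As far as these compounds go, how far past the limit compound 4 lies remains unknown, so the effect of the fluoro exchange could be small or large. Also open, from the compounds shown here alone, is whether an amine or a methoxy group in place of fluoro on this aromatic carbon would lower the number.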